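Alkoxy-for-chloro steps on the aryl ring; compound 4

A few compounds are considered here, and "the series" means these few. Any claim that something is new, unique, unknown or untested is made for them only; others in the source may bear on it.

Measured compounds:
compound 1 `O=C(O)c1cnc(-c2ccccc2Cl)[nH]c1=O` — 5 mg/kg
compound 2 `CCOc1ccccc1-c1ncc(C(=O)O)c(=O)[nH]1` — 0.5 mg/kg
compound 3 `CC(C)COc1ccccc1-c1ncc(C(=O)O)c(=O)[nH]1` — 0.5 mg/kg

In a functional assay on the whole organism (strain Sprague-Dawley) for inhibition, with Rattus norvegicus as the target, with a stated time of 10 min (on this read-out lower numbers stand for an effect already at smaller amounts and higher numbers for an effect only at larger amounts of compound), compound 1 gives the highest of the three numbers, 5 mg/kg, so the effect appears only at the largest amount of the three. The two measured steps away from it, a 10-fold lower number from compound 1 to compound 2 (1.00 log units; beyond the scatter) and a 10-fold lower number from compound 1 to compound 3 (1.00 log units; beyond the scatter), both replace the chloro with an oxygen-linked chain and both move the number downward by the same amount. Between the two chain-bearing compounds there is no change at the digits printed from compound 2 to compound 3 (within the scatter), so lengthening and branching of the chain beyond ethoxy did not alter the read-out.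

Compound 4 `O=C(O)c1cnc(-c2ccccc2OCC2CC2)[nH]c1=O` carries the change (cyclopropylmethoxy in place of chloro on an aromatic carbon). The change again places an oxygen-linked carbon chain where the chloro sat in compound 1, and it is the same kind of replacement as in compound 2 and compound 3. Both of those steps bear directly on it and each was beyond the scatter in the downward direction, while the difference between the ethoxy and isobutoxy chains left the number unchanged. The step from compound 1 is therefore expected to be downward and of similar size, a 10-fold lower number from compound 1 to compound 4 (1.00 log units; beyond the scatter). For compound 4 in this assay the estimate is 0.5 mg/kg, with a range from 0.2 mg/kg to 1.5 mg/kg.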

Compound 4, dose for 50% inhibition: 0.1 mg/kg
Compound 4: middle estimate off by 5.0-fold (0.70 log units), on the high side; measured number below the stated range.
By their numbers in this assay, from the lowest: compound 4; then compounds 2 and 3 (each within the scatter of the next); then compound 1.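

In this assay, replacing chloro with an oxygen-linked chain on this aromatic carbon can go further than ethoxy or isobutoxy showed: the cyclopropylmethoxy group gives a 50-fold lower number from compound 1 to compound 4 (1.70 log units; beyond the scatter), the largest step in the series. The earlier pair suggested that the end of the chain made no difference here, with no change at the digits printed from compound 2 to compound 3 (within the scatter), but the three-membered ring at the chain end separates compound 4 from both open chains, with a 5.0-fold lower number from compound 2 to compound 4 (0.70 log units; beyond the scatter) and a 5.0-fold lower number from compound 3 to compound 4 (0.70 log units; beyond the scatter), so the identity of the chain end does register at this position, at least for these three chains. No supporting data accompany these compounds to account for the difference between the cyclopropylmethoxy group and the open chains.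

The compounds shown leave open whether the gain belongs specifically to the three-membered ring or extends to larger rings such as cyclobutylmethoxy or cyclopentylmethoxy, and whether the methylene linker is needed, which cyclopropoxy would test. As far as these compounds go, it also remains open whether cyclopropylmethoxy would give a similar number on another carbon of the aromatic ring, or whether an amine at the chain end would be tolerated at this position.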